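A few compounds are considered here, and "the series" means these few. Any claim that something is new, unique, unknown or untested is made for them only; others in the source may bear on it.

Working notes on the series. Compound 1 `CC(C)C(=O)OCOC(=O)C1=C(S[C@@H]2CN[C@H](C(=O)Nc3cccc(C(=O)OCOC(=O)C(C)C)c3)C2)[C@H](C)[C@@H]2[C@@H]([C@@H](C)O)C(=O)N12` gives > 95% in an ADME assay for metabolic stability, read by LC-MS, with a stated time of 3 h, at pH 6.5, tested at 50 uM (a higher number here means that more of the compound is left, a lower number that less of the compound is left), which is a limit of the assay. Compound 2 `C[C@@H](O)[C@H]1C(=O)N2C(C(=O)OCOC(=O)C(C)(C)C)=C(S[C@@H]3CN[C@H](C(=O)Nc4cccc(C(=O)O)c4)C3)[C@H](C)[C@H]12` gives > 95% in this assay, again a limit. Compound 3 `CC(OC(=O)C1=C(S[C@@H]2CN[C@H](C(=O)Nc3cccc(C(=O)OC(C)OC(=O)C(C)(C)C)c3)C2)[C@H](C)[C@@H]2[C@@H]([C@@H](C)O)C(=O)N12)OC(=O)C(C)(C)C` gives > 95% in this assay, also a limit. Compound 2 therefore stands where the whole set stands: the limit of > 95% in this assay, at which 3 of the 3 values shown sit, so no order among the three can be read. Compound 4 `CCOC(=O)C1=C(S[C@@H]2CN[C@H](C(=O)Nc3cccc(C(=O)O)c3)C2)[C@H](C)[C@@H]2[C@@H]([C@@H](C)O)C(=O)N12` is not yet measured in this assay. It differs from compound 2 by methyl in place of ((tert-butyl)carbonyl)oxy on a saturated chain carbon bound to an oxygen next to a carbonyl group. Among the measured compounds shown here, no step between measured compounds exists to size this change; with every value at the limit, no movement beyond the scatter is expected in either direction. Compound 4 is expected to give 95% in this assay, in a range from 85% to 100%. The expected step of a number no higher from compound 2 to compound 4 (the limit leaves the size open) is accordingly taken as none beyond the scatter.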

Compound 4, percent of the compound remaining: > 95%
Compound 4: a limit, no number; the forecaster's own chance of this, stated with the estimate: 70%; the middle value lies on the limit itself.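

No step can be read between compound 2 and compound 4 in this assay: the limit of > 95% in this assay, at which 4 of the 4 values shown sit. The compounds shown leave open whether methyl in place of ((tert-butyl)carbonyl)oxy, or any other difference among them, changes the percent of compound remaining.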